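The source may hold more compounds than are shown below. What is called first, only, known or untested is meant among the compounds shown, and "the series" means these compounds.

Of the compounds shown here, three that share one core have been measured in a functional assay on MCF7 cells (Homo sapiens) for antiproliferative activity, read by sulforhodamine B assay, with a stated time of 48 h; a higher number here means a weaker inhibitor of growth, a lower number a stronger inhibitor of growth. Compound 1 `O=C(NCc1cn(Cc2ccc(C(F)(F)F)cc2)nn1)c1cn(-c2ccccc2)nc1-c1ccccc1` gives 840 nM in this assay. Compound 2 `O=C(NCc1cn(Cc2ccc(C(F)(F)F)cc2)nn1)c1cn(-c2ccccc2)nc1-c1ccc(F)cc1` gives 810 nM, and the step of a 1.0-fold lower number from compound 1 to compound 2 (0.02 log units; within the scatter) lies within the scatter. Compound 3 `O=C(NCc1cn(Cc2ccc(C(F)(F)F)cc2)nn1)c1cn(-c2ccccc2)nc1-c1ccc(Cl)cc1` gives 4900 nM, the highest of the three numbers; the steps of a 5.8-fold higher number from compound 1 to compound 3 (0.77 log units; beyond the scatter) and a 6.0-fold higher number from compound 2 to compound 3 (0.78 log units; beyond the scatter) are both modest but beyond the scatter.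

Compound 4 `COc1cc(Cn2cc(CNC(=O)c3cn(-c4ccccc4)nc3-c3ccc(Cl)cc3)nn2)cc(OC)c1OC` differs from compound 3 in another part of the molecule: 3,4,5-trimethoxyphenyl in place of 4-(trifluoromethyl)phenyl on a saturated chain carbon bound to an aromatic nitrogen. All three measured steps exchange hydrogen, fluoro or chloro on an aromatic carbon and leave untouched the group that changes here, so none of them bears on this exchange, and the data give no guide to its size or direction. The expectation for compound 4 in this assay therefore stays near the number of compound 3, with a wide range to reflect the lack of a relevant step. Compound 4 is expected to give 3500 nM, between 700 nM and 18000 nM. The implied step a 1.4-fold lower number from compound 3 to compound 4 (0.15 log units; within the scatter) is an expectation only.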

Compound 4, concentration for 50% growth inhibition: 2500 nM
For compound 4 the middle estimate is 1.4-fold (0.15 log units) above the measured one; the range from low to high includes it.
By their numbers in this assay, from the lowest: compounds 2 and 1 (each within the scatter of the next); then compounds 4 and 3 (each within the scatter of the next).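

The exchange of 4-(trifluoromethyl)phenyl for 3,4,5-trimethoxyphenyl is the only step shown at this place, on a saturated chain carbon bound to an aromatic nitrogen, and in this assay it gives a 2.0-fold lower number from compound 3 to compound 4 (0.29 log units; within the scatter). With the chloro group held constant, two aromatic groups that differ in their atoms, one with 0 hydrogen-bond acceptors and the other with 3, therefore cannot be told apart by this measurement. No measurement shown explains this result.

Going by these compounds, it remains open whether the same exchange would also leave the number within the scatter with the hydrogen of compound 1 or the fluoro group of compound 2 in place of the chloro group. On these data alone, it is also open whether an amine or a carboxylic acid on this aromatic ring would produce a step beyond the scatter.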